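The compounds below may be only part of what the source reports. "The series", "measured", "known", "first", "only" and "open" are said of these compounds alone.

Measured so far in a functional assay on A549 cells (Homo sapiens) for antiproliferative activity, read by MTT assay, with a stated time of 48 h; on this read-out higher numbers stand for weaker inhibition and lower numbers for stronger inhibition:
compound 1 `COc1ccc(/C=C/c2cc(OC)cc(OC)c2/C=C/C(=O)c2cccc(OC)c2)cc1` gives 6.1 ug/mL
compound 2 `CCCC(C)Oc1ccc(C(=O)/C=C/c2c(/C=C/c3ccc(OC)cc3)cc(OC)cc2OC)cc1` gives 9.4 ug/mL
compound 3 `COc1ccc(/C=C/c2cc(OC)cc(OC)c2/C=C/C(=O)c2ccc(C)c(C)c2)cc1` gives 0.1 ug/mL

Compound 2 holds the highest number of the three, though a 1.5-fold higher number from compound 1 to compound 2 (0.19 log units; within the scatter) keeps it within the scatter of compound 1. The step to compound 4 `COc1ccc(/C=C/c2cc(OC)cc(OC)c2/C=C/C(=O)c2ccc(-c3ccccc3)cc2)cc1` is phenyl in place of 1-methylbutoxy on an aromatic carbon. The step that bears on it is a 94-fold lower number from compound 2 to compound 3 (1.97 log units; beyond the scatter), where the alkoxy-bearing aryl on the carbonyl gave way to an aryl without an oxygen, and the number fell far beyond the scatter; a 61-fold lower number from compound 1 to compound 3 (1.79 log units; beyond the scatter) points the same way. The exchange of one alkoxy for another, a 1.5-fold higher number from compound 1 to compound 2 (0.19 log units; within the scatter), moved nothing. A lower number is therefore expected for compound 4, a 6.3-fold lower number from compound 2 to compound 4 (0.80 log units; beyond the scatter), likely smaller than the step to compound 3 given the different entering group. Estimate for compound 4 in this assay: 1.5 ug/mL, range 0.3 ug/mL to 8 ug/mL.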

Compound 4, half-maximal inhibitory concentration: 4.6 ug/mL
Compound 4: the middle estimate sits 3.1-fold (0.49 log units) below what was measured, within the range that was stated.
By their numbers in this assay, from the lowest: compound 3; then compounds 4, 1 and 2 (each within the scatter of the next, the first and the last beyond it).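

Losing the oxygen from the aryl on the carbonyl does not by itself bring the low number of compound 3: in this assay there is a 46-fold higher number from compound 3 to compound 4 (1.66 log units; beyond the scatter) between two aryl groups without oxygen. Phenyl in place of 1-methylbutoxy gives only a 2.0-fold lower number from compound 2 to compound 4 (0.31 log units; beyond the scatter) while there is a 1.3-fold lower number from compound 1 to compound 4 (0.12 log units; within the scatter) so of the four compounds, only compound 3 stands apart. Open, on these data alone, is whether compound 3 needs both methyl groups, and how a single methyl, a chlorine or an amine on this aryl would read. No evidence at hand explains the differences between these aryl groups.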